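An Amino Group Added to a Chlorinated Purine Core

The source may hold more compounds than are shown below. What is called first, only, known or untested is meant among the compounds shown, and "the series" means these compounds.

Measured compounds:
Compound 1, `ClCc1cccc(Cn2cnc3c(Cl)ncnc32)c1`: 4160 nM
Compound 2, `ClCc1ccc(Cn2cnc3nc(Cl)nc(Cl)c32)cc1`: 17800 nM

Both were tested in a functional assay on PC-3 cells (Homo sapiens) for cytotoxicity, read by sulforhodamine B assay, with a stated time of 48 h; on this read-out higher numbers stand for weaker inhibition of growth and lower numbers for stronger inhibition of growth. Compound 1 holds the lowest of the two numbers; compound 2 sits higher, beyond the usual scatter, but the two differ in more than one place, so only their values can be compared. Compound 3 `Nc1nc(Cl)c2ncn(Cc3cccc(CCl)c3)c2n1` is not yet measured. Its change from compound 1 is amino in place of hydrogen on an aromatic carbon. Going by the values given here, no measured pair shows this change, so the step from compound 1 to compound 3 is expected to be small, none beyond the scatter, as a 1.2-fold lower number from compound 1 to compound 3 (0.08 log units; within the scatter). Compound 3 is estimated at 3500 nM, within 1200 nM to 10000 nM.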

Compound 3, concentration for 50% growth inhibition: 9770 nM
Compound 3: the middle estimate sits 2.8-fold (0.45 log units) below what was measured, and the stated range covers the measured number.
By their numbers in this assay, from the lowest: compound 1; then compounds 3 and 2 (each within the scatter of the next).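

Putting amino in place of hydrogen on the aromatic carbon between two ring nitrogen atoms gives, in this assay, a 2.3-fold higher number from compound 1 to compound 3 (0.37 log units; beyond the scatter). Going by these compounds alone, this is the first comparison here of compounds that differ in one place, and it shows that a change at this position can shift the number: the amino compound inhibits growth more weakly, though the step is modest. Nothing available here accounts for this shift. Within the data shown here, with only this one pair, it remains open whether a methylamino or a hydroxyl group on the same carbon would move the number in the same direction, or by a similar amount.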